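The compounds below may be only part of what the source reports. "The series", "measured", "known", "first", "only" and "open" are said of these compounds alone.

Measured in a functional assay on B16 cells (Mus musculus) for cytotoxicity, read by CCK-8 assay, with a stated time of 24 h; on this read-out lower numbers stand for stronger inhibition and higher numbers for weaker inhibition:
- compound 1 `COc1ccc(-c2nc(N)c(Oc3ccccc3OC)c(Cl)n2)cc1`: 47800 nM
- compound 2 `COc1ccccc1Oc1c(N)nc(-c2ccc(C)cc2)nc1OCCO`: 8430 nM
- compound 3 `COc1ccc(-c2nc(N)c(Oc3ccccc3OC)c(OCCO)n2)cc1`: 18100 nM

Compound 3 stands in the middle of these three numbers, with compound 2 lower and compound 1 higher. Compound 4 `COc1ccccc1Oc1c(N)nc(-c2cccc(I)c2)nc1OCCO` has 3-iodophenyl in place of 4-methoxyphenyl (3-iodophenyl in place of 4-methoxyphenyl on an aromatic carbon). The closest guide is a 2.1-fold higher number from compound 2 to compound 3 (0.33 log units; beyond the scatter), where methoxy in place of methyl on that phenyl group was the only difference, so dropping the methoxy went with a lower number. The other step, a 2.6-fold lower number from compound 1 to compound 3 (0.42 log units; beyond the scatter), lies at a different place and bears on this only weakly. Among the compounds with values here, no measured compound carries iodine, so the guide is loose. The expected step is modest, a 1.8-fold lower number from compound 3 to compound 4 (0.26 log units; within the scatter). Compound 4 is estimated at 10000 nM, with an expected range of 3500 nM to 28000 nM.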

Compound 4, half-maximal inhibitory concentration: 20300 nM
For compound 4 the middle estimate is 2.0-fold (0.31 log units) below the measured one; measured number inside the range.
By their numbers in this assay, from the lowest: compound 2; then compounds 3 and 4 (each within the scatter of the next); then compound 1.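

Replacing 4-methoxyphenyl with 3-iodophenyl at this position gives a 1.1-fold higher number from compound 3 to compound 4 (0.05 log units; within the scatter), so this phenyl group can carry a quite different substituent at another ring position with no change beyond the scatter. Compound 2, with its 4-methylphenyl group, stays apart from the iodo compound, with a 2.4-fold higher number from compound 2 to compound 4 (0.38 log units; beyond the scatter), so the methyl compound remains the only one of these three aryl variants to stand out. Nothing available explains these numbers.

The compounds shown leave open how 4-iodophenyl, 3-methoxyphenyl or plain phenyl would read here, so the effect of the iodine cannot be separated from that of its ring position.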